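This account rests on a few compounds, and the source may have more. Where it says the series, first, only, none or still open, it means among the compounds named here.

Compound 1, `O=C(Nc1nc2ccc(Cl)cc2s1)c1cc(-c2ccc(F)cc2)n2nc(-c3ccccc3)cc2n1`, gives 17600 nM in a functional assay on DU-145 cells (Homo sapiens) for cytotoxicity, read by MTT assay, with a stated time of 48 h; on this read-out lower numbers stand for stronger inhibition and higher numbers for weaker inhibition.
Compound 2, `COc1ccc(-c2cc(C(=O)Nc3nc4ccc(F)cc4s3)nc3cc(-c4ccccc4)nn23)cc1OC`, gives 18600 nM in this assay.
Compound 3, `COc1cc(-c2cc(C(=O)Nc3nc4ccc(F)cc4s3)nc3cc(-c4ccccc4)nn23)cc(OC)c1OC`, gives 25700 nM in this assay.

Compound 3 has the highest number of the three, yet its distances to compound 2 and to compound 1 both fall within the usual scatter, so the three cannot be ranked. Going by the values given here, the only measured single change, a 1.4-fold higher number from compound 2 to compound 3 (0.14 log units; within the scatter), concerns the methoxy groups and not the amide side of the molecule.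

Compound 4, `COc1cc(-c2cc(C(=O)Nc3nc4cc(C)c(C)cc4s3)nc3cc(-c4ccccc4)nn23)cc(OC)c1OC`, differs from compound 3 by 5,6-dimethyl-1,3-benzothiazol-2-yl in place of 6-fluoro-1,3-benzothiazol-2-yl on an amide-type nitrogen. Among the compounds with values here, no measured step touches this change, so nothing here argues for a shift beyond the scatter in either direction. For compound 4 the expected step is a 1.2-fold lower number from compound 3 to compound 4 (0.07 log units; within the scatter), giving an estimate of 22000 nM with a range from 8000 nM to 60000 nM.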

Compound 4, half-maximal inhibitory concentration: 3710 nM
Beside the measured number, compound 4's estimate is 5.9-fold (0.77 log units) above it; the whole stated range lies above it.
By their numbers in this assay, from the lowest: compound 4; then compounds 1, 2 and 3 (each within the scatter of the next).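

Going by these compounds alone, until now no measured step touched the group on the amide-type nitrogen. In this assay, within the data shown here, 5,6-dimethyl-1,3-benzothiazol-2-yl in place of 6-fluoro-1,3-benzothiazol-2-yl gives a 6.9-fold lower number from compound 3 to compound 4 (0.84 log units; beyond the scatter) and is the first step here to pass the scatter, so this position can move the number, unlike the methoxy change so far. Nothing shown explains why this step occurs.

Still open, going by these compounds, is whether a single methyl group, or an amine or a carboxylic acid, on this 1,3-benzothiazol-2-yl group would do the same. Also open, on these data alone, is whether 5,6-dimethyl-1,3-benzothiazol-2-yl gives a similar step with the other groups of compound 1 or compound 2.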